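Amino in Place of Chloro: An Expectation for Compound 4

The compounds below may be only part of what the source reports. "The series", "measured", "known", "first", "only" and "open" are said of these compounds alone.

Compound 1 `Nc1nc(Cl)c2ncn(Cc3ccc(CCl)cc3)c2n1` gives 91200 nM in a functional assay on SNB-75 cells (Homo sapiens) for cytotoxicity, read by sulforhodamine B assay, with a stated time of 48 h; a higher number here means a weaker inhibitor of growth, a lower number a stronger inhibitor of growth.
Compound 2 `ClCc1cccc(Cn2cnc3c(Cl)nc(Cl)nc32)c1` gives 3890 nM in this assay.
Compound 3 `ClCc1ccc(Cn2cnc3c(Cl)nc(Cl)nc32)cc1` gives 9330 nM in this assay.

Compound 2 has the lowest number of the three in this assay. Compounds 2 and 3 are built from the same atoms joined differently; the difference between their two cores is not broken down here. From compound 3 to compound 1 the change is amino in place of chloro on an aromatic carbon, and it brought a 9.8-fold higher number from compound 3 to compound 1 (0.99 log units; beyond the scatter). Compound 4 `Nc1nc(Cl)c2ncn(Cc3cccc(CCl)c3)c2n1` has not yet been measured; it arises from compound 2 by the same change, (amino in place of chloro on an aromatic carbon), at the same place. For the measured compounds named here, compound 4 is expected to show a step of a 9.8-fold higher number from compound 2 to compound 4 (0.99 log units; beyond the scatter), resting on the single earlier step of a 9.8-fold higher number from compound 3 to compound 1 (0.99 log units; beyond the scatter). Compound 4 is therefore estimated at 38000 nM, with a range from 15000 nM to 95000 nM.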

Compound 4, concentration for total growth inhibition: 19500 nM
Beside the measured number, compound 4's estimate is 1.9-fold (0.29 log units) above it, and the stated range covers the measured number.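

In this assay, amino in place of chloro on an aromatic carbon again went with a weaker inhibition of growth, with a 5.0-fold higher number from compound 2 to compound 4 (0.70 log units; beyond the scatter). Set beside the earlier step, the change carried from one core to the other in direction, and the two sizes do not differ beyond the scatter: the same change on two cores in this assay, a 9.8-fold higher number (0.99 log units; beyond the scatter) from compound 3 to compound 1 and a 5.0-fold higher number (0.70 log units; beyond the scatter) from compound 2 to compound 4, 1.9-fold (0.29 log units) apart, within the scatter of two such steps. This rests on two pairs of compounds only, so it shows that the step held on these two cores and does not show how it would behave on any other core.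

The compounds shown leave open what a methylamino group or a methoxy group would do on the aromatic carbon between two ring nitrogen atoms. They also leave open what a hydroxymethyl group in place of the chloromethyl group would do on either core.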